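Swapping tert-butylamino in a chloro compound

A few compounds are considered here, and "the series" means these few. Any claim that something is new, unique, unknown or untested is made for them only; others in the source may bear on it.

- compound 1 `CCCCNc1nc(Cl)nc(N[C@H](C)c2ccccc2)n1`: 38900 nM
- compound 2 `C[C@H](Nc1nc(Cl)nc(NC(C)(C)C)n1)c1ccccc1`: 7410 nM
- compound 3 `CCN(CC)c1nc(Cl)nc(N[C@H](C)c2ccccc2)n1`: 24000 nM

In an ADME assay on the whole organism for inhibition, with Echinochloa crus-galli var. formosensis as the target, with a stated time of 4 days (a higher number here means a weaker inhibitor, a lower number a stronger inhibitor), compound 2 has the lowest of the three numbers, and its gaps to compound 1 and compound 3 both lie beyond the scatter. Compound 4 `CCCN(C)c1nc(Cl)nc(N[C@@H](C)c2ccccc2)n1` has not been measured, and it differs from compound 2 by one group: methyl(propyl)amino in place of (tert-butyl)amino on an aromatic carbon.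

Among the compounds with values here, only one measured step bears on this change: a 1.6-fold lower number from compound 1 to compound 3 (0.21 log units; within the scatter). There, too, an amino group with one chain gives way to an amino group with two, and the step stays within the scatter. The guide is imperfect, since compound 2 and compound 4 share one mirror-image form while compound 1 and compound 3 carry the opposite form. The data do not separate that difference from the change of amino group. Compound 3, the measured compound with two chains, stands at 24000 nM, so a slightly higher number is expected, but nothing beyond the scatter. The expected change is a 1.9-fold higher number from compound 2 to compound 4 (0.28 log units; within the scatter). For compound 4 the estimated value is 14000 nM, with an expected range of 4000 nM to 50000 nM.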

Compound 4, half-maximal inhibitory concentration: 380 nM
Compound 4: middle estimate off by 37-fold (1.57 log units), on the high side, outside the stated range (below it).
By their numbers in this assay, from the lowest: compound 4; then compound 2; then compounds 3 and 1 (each within the scatter of the next).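

In this assay this position proves highly sensitive to how the amino group is built, with a 20-fold lower number from compound 2 to compound 4 (1.29 log units; beyond the scatter) even though the two groups hold the same atoms joined differently, and only the leaving group carries a hydrogen-bond donor. Within the data shown here, the one other step from a single-chain to a two-chain amino group, a 1.6-fold lower number from compound 1 to compound 3 (0.21 log units; within the scatter) in the opposite mirror-image form, stays within the scatter, so this kind of change has no single size across these compounds. No measured evidence here accounts for the large step. The compounds shown leave open whether the mirror-image form or the particular amino groups set the size of the step. They also leave open whether dimethylamino, dipropylamino or a pyrrolidine ring at this position would give a number as low as that of compound 4.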